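A few compounds are considered here, and "the series" means these few. Any claim that something is new, unique, unknown or untested is made for them only; others in the source may bear on it.

Measured compounds:
compound 1, `CC(C)CC[C@@]1(NCc2ccccc2)C(=O)C(C2=NS(=O)(=O)c3cc(NS(C)(=O)=O)ccc3N2)=C(O)c2ccccc21`: 19.3 mL/min/kg
compound 2, `COc1ccccc1CNC1(CCC(C)(C)C)C(=O)C(C2=NS(=O)(=O)c3cc(NS(C)(=O)=O)ccc3N2)=C(O)c2ccccc21`: 25 mL/min/kg

Both have been run in an in vivo ADME assay on the whole organism (strain Sprague-Dawley) for pharmacokinetics, with Rattus norvegicus as the target, at a dose of 5 mg/kg by the intravenous route; a higher number here means faster removal of the compound, a lower number slower removal. Compound 1 gives 19.3 mL/min/kg, and compound 2 gives 25 mL/min/kg; the gap between the two numbers lies within the scatter, so the two cannot be told apart and compound 1 is not set apart from compound 2 on this read-out. Within the data shown here, no pair of measured compounds differs in a single place, so no step size is known from the data themselves.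

Compound 3, `CC(C)CC[C@@]1(N)C(=O)C(C2=NS(=O)(=O)c3cc(NS(C)(=O)=O)ccc3N2)=C(O)c2ccccc21`, is the compound still to be measured in this assay. It differs from compound 1 by hydrogen in place of benzyl on an amine nitrogen. Among the measured compounds shown here, with no measured step of this kind to draw on, the expectation for a 1.1-fold lower number from compound 1 to compound 3 (0.06 log units; within the scatter) is a step that stays within the scatter, with no clear direction. Compound 3 is therefore expected to give about 17 mL/min/kg, with a range from 8 mL/min/kg to 35 mL/min/kg.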

Compound 3, clearance: 35.3 mL/min/kg
The estimate for compound 3 lay 2.1-fold (0.32 log units) below the measured number; measured number above the stated range.
By their numbers in this assay, from the lowest: compounds 1, 2 and 3 (each within the scatter of the next).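

In this assay, hydrogen in place of benzyl on an amine nitrogen gives a 1.8-fold higher number from compound 1 to compound 3 (0.26 log units; within the scatter), the first step measured at this position. The benzyl group, with its seven carbons and aromatic ring, can therefore leave this nitrogen without a step beyond the scatter, so this read-out shows no clear dependence on benzyl here. No measurement available bears on why this step has the size it has.

Still open, as far as these compounds go, is whether another group on this amine nitrogen, such as methyl, acetyl, a longer alkyl chain or a chain ending in a carboxylic acid, would give a step beyond the scatter. Compound 2 differs from compound 1 and compound 3 in more than one place, so it gives no separate reading of the benzyl group.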